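The source may report more compounds than this note shows. Statements on the series, on what has been measured and on what is new or still open speak of the compounds shown alone.

Series notes, a physicochemical assay for solubility, read by nephelometry, measured as kinetic solubility, at pH 2.0; on this read-out higher numbers stand for higher solubility and lower numbers for lower solubility. Compound 1 `NCc1csc(NC(=O)c2cnnn2Cc2ccccc2)n1` gives > 100 ug/mL in this assay, a limit reading rather than a number. Among the measured compounds shown here, compound 2 `CC(C)(C)c1cc(C(=O)Nc2ccccc2)n(Cc2ccccc2)n1` gives 1.6 ug/mL in this assay, the only plain number so far. The other value shown is the limit of > 100 ug/mL in this assay, at which 1 of the 2 values shown sits. Compound 3 `CNCc1csc(NC(=O)c2cc(C(C)(C)C)nn2Cc2ccccc2)n1` differs from compound 2 by 4-((methylamino)methyl)-1,3-thiazol-2-yl in place of phenyl on an amide-type nitrogen. Compound 3 has not yet been measured in this assay. Compound 1 also bears a thiazolyl group on its amide-type nitrogen. The step from compound 2 to compound 3 is expected to be large and upward, a 38-fold higher number from compound 2 to compound 3 (1.57 log units; beyond the scatter). Compound 3 is estimated at 60 ug/mL, in the range 15 ug/mL to 100 ug/mL, with a fair chance of another limit reading.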

Compound 3, solubility: 25 ug/mL
The estimate for compound 3 lay 2.4-fold (0.38 log units) above the measured number, and the stated range covers the measured number.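

Putting 4-((methylamino)methyl)-1,3-thiazol-2-yl in place of phenyl on an amide-type nitrogen gives a 16-fold higher number from compound 2 to compound 3 (1.19 log units; beyond the scatter) in this assay. Among the compounds shown here, this is the first step that changes one place only, and it shows that this position alone can shift the read-out well beyond the scatter. Compound 1 remains a limit reading, not a number, and enters no step: the limit of > 100 ug/mL in this assay, at which 1 of the 3 values shown sits.

Still open, on these data alone, is how the step divides between the thiazolyl ring and the (methylamino)methyl chain. Also open, as far as these compounds go, is how a phenyl carrying that chain, or a thiazolyl carrying a morpholine or a carboxylic acid instead, would read in this assay.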